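Lengthening the Chain on the Core of Compound 1

The source may hold more compounds than are shown below. What is called first, only, known or untested is meant among the compounds shown, and "the series" means these compounds.

Of the compounds shown here, three sharing one core have been measured in a functional assay with Alpha-1A adrenergic receptor (Homo sapiens) as the target, read by calcium flux; a lower number here means a smaller maximal response, a higher number a larger maximal response. Compound 1, `CCn1ncnc1-c1ccccc1NCC1=NCCN1`, gives 107%. Compound 3, `Cn1cccc1-c1ccccc1NCC1=NCCN1`, gives 103%, a number that sits within the usual scatter of the value for compound 1. Compound 2, `CCn1ccc(-c2ccccc2NCC2=NCCN2)n1`, gives 78%, which lies beyond the scatter below the value for compound 1. So compound 1 stands at the upper end of what has been seen, with compound 3 indistinguishable from it and compound 2 clearly lower.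

Compound 4, `CCCCn1ncnc1-c1ccccc1NCC1=NCCN1`, has not yet been measured. It differs from compound 1 in one place: ethyl in place of hydrogen on a saturated chain carbon, two bonds along the chain from an aromatic nitrogen. Going by the values given here, no pair of measured compounds differs by such a change, so the size of this step can only be expected, not read from the data. Compound 1 already reaches a full response in this assay, and a longer saturated chain at this position is not expected to shift that by more than the scatter. The step from compound 1 to compound 4 is therefore expected to be a number 7 percentage points lower from compound 1 to compound 4 (within the scatter). Compound 4 is expected to give about 100%, within a range from 80% to 115%.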

Compound 4, largest response reached (reported as maximal response), in percent of the reference or control that the assay uses: 86%
Compound 4: middle estimate off by 14 percentage points, on the high side, within the range that was stated.
By their numbers in this assay, from the lowest: compounds 2 and 4 (each within the scatter of the next); then compounds 3 and 1 (each within the scatter of the next).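

In this assay, going by these compounds alone, the change from ethyl to butyl on the core of compound 1 gives a number 21 percentage points lower from compound 1 to compound 4 (beyond the scatter) and is the first step that can be read at this position, since no earlier pair differed in one place. It shows that this position, on a saturated chain carbon, two bonds along the chain from an aromatic nitrogen, is not indifferent to added carbon: ethyl in place of hydrogen there is enough to move the maximal response beyond the scatter. As a single step from a single starting point, it shows that the position responds to this change, not how the response runs with chain length. Nothing at hand gives a reason for this step.

Going by these compounds, whether a propyl chain would already lower the response, and whether a hexyl chain or a branched isobutyl group would lower it further, stays open. Also open, on these data alone, is whether a hydroxyl group or an amine at the end of the chain would give a different response from the plain butyl chain.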